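From acetyl to 2-chlorobenzoyl on a shared core

The source may hold more compounds than are shown below. What is called first, only, known or untested is meant among the compounds shown, and "the series" means these compounds.

All three measured compounds were tested in a functional assay on MDA-MB-231 cells (Homo sapiens) for cytotoxicity, read by sulforhodamine B assay, with a stated time of 72 h; on this read-out higher numbers stand for weaker inhibition of growth and lower numbers for stronger inhibition of growth. Compound 1 `CCCCCCCCC(=O)N1c2ccccc2CCC1C(=O)Nc1ccccc1C(F)(F)F` gives 3350 nM. Compound 2 `O=C(Nc1ccccc1)C1CCc2ccccc2N1` gives 108000 nM. Compound 3 `CC(=O)N1c2ccccc2CCC1C(=O)Nc1cc(C(F)(F)F)cc(C(F)(F)F)c1` reaches only a limit of the assay, > 70000 nM. Compound 3 thus sits at the limit of > 70000 nM in this assay, at which 1 of the 3 values shown sits, and where it stands among the three measured compounds is known only as that limit. Compound 4 `O=C(Nc1cc(C(F)(F)F)cc(C(F)(F)F)c1)C1CCc2ccccc2N1C(=O)c1ccccc1Cl` has not yet been measured. It differs from compound 3 in one place: 2-chlorophenyl in place of methyl on a carbonyl carbon. Among the measured compounds shown here, no step between two measured compounds isolates this change, so its size is open. Of the measured compounds, compound 1 carries the largest acyl group and shows the lowest number, while compound 2, which carries none, shows a far higher one. The step from compound 3 to compound 4 is expected to be an at least 5.8-fold lower number from compound 3 to compound 4 (0.76 log units; beyond the scatter), toward stronger inhibition. Compound 4 is estimated at 12000 nM, within 2500 nM to 70000 nM, with some chance that this assay again reports only a limit.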

Compound 4, concentration for 50% growth inhibition: 5250 nM
Compound 4: middle estimate off by 2.3-fold (0.36 log units), on the high side, within the range that was stated.
By their numbers in this assay, from the lowest: compounds 1 and 4 (each within the scatter of the next); then compound 2.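

Placing 2-chlorophenyl in place of methyl on a carbonyl carbon whose other neighbour is an amide-type nitrogen in a ring gives an at least 13-fold lower number from compound 3 to compound 4 (1.12 log units; beyond the scatter) in this assay. Among the compounds shown here, this is the first change in a single place that can be read, and it shows that the number in this assay responds to the group at this position, even though the entering group adds no hydrogen-bond donors or acceptors. The value of compound 3 is a limit of the assay, so the step gives only a minimum size and its full size stays unknown: the limit of > 70000 nM in this assay, at which 1 of the 4 values shown sits.

The compounds shown do not separate the contribution of the aromatic ring from that of the chlorine, which an unsubstituted phenyl at this carbonyl carbon could do. Also open, as far as these compounds go, is how an amine or a carboxylic acid on that ring would read in this assay.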